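The source may hold more compounds than are shown below. What is called first, only, known or untested is meant among the compounds shown, and "the series" means these compounds.

Measured in a functional assay on V79-379A cells (Cricetulus griseus) for cytotoxicity, read by MTT assay, in the presence of a further agent that is not named here; on this read-out higher numbers stand for weaker inhibition and lower numbers for stronger inhibition:
- compound 1 `COC1=CC(=O)c2c(c(CO)cn2C)C1=O`: 240000 nM
- compound 2 `COC1=CC(=O)c2c(c(COC(=O)c3ccc(F)cc3)cn2C)C1=O`: 50 nM
- compound 3 `COC1=CC(=O)c2c(c(COC(=O)c3ccc(F)cc3)c(C)n2C)C1=O`: 300 nM

Compound 3 has the second highest of the three numbers, with compound 2 lower and compound 1 much higher. The next compound, compound 4 `COC1=CC(=O)c2c(c(COC(C)=O)c(C)n2C)C1=O`, brings the change (methyl in place of 4-fluorophenyl on a carbonyl carbon), which is methyl in place of 4-fluorophenyl on a carbonyl carbon. Going by the values given here, no measured step covers this change. Among the compounds with values here, the one measured step, a 6.0-fold higher number from compound 2 to compound 3 (0.78 log units; beyond the scatter), is a different change and offers only a rough guide to size. A modest rise in this assay is therefore expected, an estimated 2.0-fold higher number from compound 3 to compound 4 (0.30 log units; within the scatter), though its direction is uncertain. For compound 4 the expected value is 600 nM, with an estimated range of 120 nM to 3000 nM.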

Compound 4, half-maximal inhibitory concentration: 2500 nM
The estimate for compound 4 lay 4.2-fold (0.62 log units) below the measured number; the range from low to high includes it.
By their numbers in this assay, from the lowest: compound 2; then compound 3; then compound 4; then compound 1.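

In this assay, the acyl side of the ester proves to matter: methyl in place of 4-fluorophenyl on the carbonyl carbon gives (an 8.3-fold higher number from compound 3 to compound 4 (0.92 log units; beyond the scatter)), a step beyond the scatter. Going by these compounds alone, the earlier step had changed only an aromatic carbon, so this is the first measured change at the carbonyl carbon. No evidence is available to explain the step.

The compounds shown leave open whether the ring or its fluorine carries the difference, which plain phenyl would separate. Also open, as far as these compounds go, is how a longer chain such as propyl would fall.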